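Solubility notes: trifluoromethyl in place of cyano on the benzyl

This account rests on a few compounds, and the source may have more. Where it says the series, first, only, none or still open, it means among the compounds named here.

compound 1, `Cc1c(Cc2ccc(F)cc2)c(=O)oc2cc(OCCOc3no[n+]([O-])c3S(=O)(=O)c3ccccc3)ccc12`, in a physicochemical assay for solubility, read by HPLC, in phosphate buffer, with a stated time of 24 h (on this read-out higher numbers stand for higher solubility and lower numbers for lower solubility), gives 0.01 ug/mL
compound 2, `COc1cc(OCCOc2no[n+]([O-])c2S(=O)(=O)c2ccccc2)ccc1C(=O)N/N=C/c1ccncc1`, in this assay gives 4.6 ug/mL
compound 3, `Cc1c(Cc2ccc(C#N)cc2)c(=O)oc2cc(OCCOc3no[n+]([O-])c3S(=O)(=O)c3ccccc3)ccc12`, in this assay gives 7.3 ug/mL

Compound 3 holds the highest number of the three, but compound 2 sits within the scatter of it, so the two cannot be ordered. Compound 1 lies far below: a 730-fold higher number from compound 1 to compound 3 (2.86 log units; beyond the scatter). Compound 4, `Cc1c(Cc2ccc(C(F)(F)F)cc2)c(=O)oc2cc(OCCOc3no[n+]([O-])c3S(=O)(=O)c3ccccc3)ccc12`, differs from compound 3 in one place: trifluoromethyl in place of cyano on an aromatic carbon.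

Among the measured compounds shown here, no measured step covers this exact change. For the measured compounds named here, the only step touching the same position is the one from fluoro to cyano, which was large and upward, so the cyano analogue stands at the top of the series while the fluoro analogue is at the bottom. Going by the values given here, replacing cyano by trifluoromethyl removes the one group that produced that rise, so a lower number for compound 4 is expected, likely a large drop but not necessarily back to the fluoro level: a 73-fold lower number from compound 3 to compound 4 (1.86 log units; beyond the scatter). Compound 4 is therefore estimated at 0.1 ug/mL, with a range from 0.01 ug/mL to 1 ug/mL, and some chance that only a limit is reported.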

Compound 4, solubility: 0.7 ug/mL
For compound 4 the middle estimate is 7.0-fold (0.85 log units) below the measured one; measured number inside the range.
By their numbers in this assay, from the lowest: compound 1; then compound 4; then compounds 2 and 3 (each within the scatter of the next).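

In this assay, replacing cyano with trifluoromethyl on the aromatic carbon gives a 10-fold lower number from compound 3 to compound 4 (1.02 log units; beyond the scatter), whereas replacing fluoro with trifluoromethyl at the same carbon gives a 70-fold higher number from compound 1 to compound 4 (1.85 log units; beyond the scatter). This single position therefore gives three separate levels rather than a high and a low one, with trifluoromethyl at an intermediate level and each step to it beyond the scatter. Nothing measured here bears on the reason for this order.

As far as these compounds go, all three substituents sit at one place on one core, so it remains open where an amine, a carboxylic acid or a methoxy group on this carbon would fall relative to compound 1 and compound 3. From the compounds shown here alone, whether the change from cyano to trifluoromethyl gives a similar step on another core, such as that of compound 2, is also open.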